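Compound 1 to compound 4: methoxy in place of methyl

The compounds below may be only part of what the source reports. "The series", "measured", "known", "first", "only" and "open" are said of these compounds alone.

In a physicochemical assay for lipophilicity, at pH 7.4 (a lower number here means a more polar compound, a higher number a more lipophilic compound), compound 1 (`Cc1cc(C)c(CN2CCc3c(Cl)cc(-c4c(C)noc4C)c(Cl)c3C2=O)c(=O)[nH]1`) gives 3.1, the higher of the two single numbers in the series, and compound 2 (`Cc1cc(C)c(CN2CCc3c(Cl)cc([C@H](C)CO)c(Cl)c3C2=O)c(=O)[nH]1`) gives 2.6. Compound 3 (`COC(c1cc(Cl)c2c(c1Cl)C(=O)N(Cc1c(C)cc(C)[nH]c1=O)CC2)C1CCOC1`) has four entries, 3; 3; 3; 3 (4 entries), without a single number. Compound 4 (`COc1cc(C)[nH]c(=O)c1CN1CCc2c(Cl)cc(-c3c(C)noc3C)c(Cl)c2C1=O`) carries methoxy in place of methyl on an aromatic carbon, opposite the ring nitrogen: methoxy in place of methyl on an aromatic carbon. Among the measured compounds shown here, the only measured step, a number 0.50 log units lower from compound 1 to compound 2 (beyond the scatter), is modest and replaces a different group, so it does not measure this change directly. The expected step in this assay is small, slightly downward and not beyond the scatter: a number 0.20 log units lower from compound 1 to compound 4 (within the scatter). For compound 4 the estimated value is 2.9, with an expected range of 2.5 to 3.3.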

Compound 4, distribution coefficient: 2.7
The estimate for compound 4 lay 0.20 log units above the measured number; the range from low to high includes it.
By their numbers in this assay, from the lowest: compounds 2 and 4 (each within the scatter of the next); then compound 1.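

In this assay the position opposite the ring nitrogen gives a number 0.40 log units lower from compound 1 to compound 4 (beyond the scatter) with methoxy in place of methyl, so a change at this place, with the rest of compound 1 held fixed, now has a direct reading. The swap enters 1 hydrogen-bond acceptor and no donor, and it is the series' first measured step away from the aromatic carbon changed in compound 2. Nothing on hand accounts for the size of this step.

Going by these compounds, whether an ethoxy group or a dimethylamino group at this position would give a step of similar size remains open. Also open, on these data alone, is whether methoxy in place of methyl gives the same step with the other substituents of compound 2 or compound 3.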